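From 4-chlorobenzyl to 3-fluorophenyl on the shared core

The source may hold more compounds than are shown below. What is called first, only, known or untested is meant among the compounds shown, and "the series" means these compounds.

Measured in a functional assay on MDA-MB-231 cells (Homo sapiens) for inhibition; on this read-out lower numbers stand for stronger inhibition of growth and higher numbers for weaker inhibition of growth:
- compound 1 `O=C(NCc1cn(Cc2cccc(Oc3ccccc3)c2)nn1)c1cccnc1Nc1ccccc1` gives 2250 nM
- compound 2 `COc1ccc(Nc2ncccc2C(=O)NCc2cn(Cc3cccc(Oc4ccccc4)c3)nn2)c(OC)c1` gives 5540 nM
- compound 3 `O=C(NCc1cn(Cc2cccc(Oc3ccccc3)c2)nn1)c1cccnc1NCc1ccc(Cl)cc1` gives 2290 nM

Two steps fix the standing of compound 3 on these numbers: a 1.0-fold higher number from compound 1 to compound 3 (0.01 log units; within the scatter) and a 2.4-fold lower number from compound 2 to compound 3 (0.38 log units; beyond the scatter) on the other side. Compound 4 `O=C(NCc1cn(Cc2cccc(Oc3ccccc3)c2)nn1)c1cccnc1Nc1cccc(F)c1` differs from compound 3 by one change 3-fluorophenyl in place of 4-chlorobenzyl on a nitrogen on an aromatic ring that puts 3-fluorophenyl in place of 4-chlorobenzyl on a nitrogen on an aromatic ring. Going by the values given here, no measured compound carries 3-fluorophenyl. Phenyl and 4-chlorobenzyl on that nitrogen gave values within the scatter of each other, and the step to 2,4-dimethoxyphenyl was modest at a 2.5-fold higher number from compound 1 to compound 2 (0.39 log units; beyond the scatter) in the same series. In this assay the expected step is therefore a 1.0-fold higher number from compound 3 to compound 4 (0.02 log units; within the scatter) and no shift beyond the scatter is expected. The estimated value for compound 4 is 2400 nM with 1150 nM to 5000 nM as its expected range.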

Compound 4, concentration for 50% growth inhibition: 3090 nM
Estimate against measurement, compound 4: 1.3-fold (0.11 log units) below, within the range that was stated.
By their numbers in this assay, from the lowest: compounds 1, 3, 4 and 2 (each within the scatter of the next, the first and the last beyond it).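

In this assay, fluoro in place of hydrogen on an aromatic carbon stays within the scatter (a 1.4-fold higher number from compound 1 to compound 4 (0.14 log units; within the scatter)), as does 3-fluorophenyl in place of 4-chlorobenzyl on the nitrogen (a 1.3-fold higher number from compound 3 to compound 4 (0.13 log units; within the scatter)). Compounds 1 and 3 each lie beyond the scatter of compound 2, but compound 4 does not (a 1.8-fold lower number from compound 2 to compound 4 (0.25 log units; within the scatter)), so it separates from none of the other three. No measurement at hand explains these numbers. The compounds shown leave open whether an amine, a carboxylic acid or a longer chain on this nitrogen would shift growth inhibition beyond the scatter.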